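A Pyrimidinyl Addition on an Aminopyrimidine Anilide Core

The source may hold more compounds than are shown below. What is called first, only, known or untested is meant among the compounds shown, and "the series" means these compounds.

The series starts from compound 1 `Cc1cc(Nc2cccc(Cl)c2)nc(N)n1`. In an assay on cells for inhibition of S-adenosylmethionine decarboxylase proenzyme (Homo sapiens), read by mass spectrometry, at pH 7.2 (a higher number here means a weaker inhibitor, a lower number a stronger inhibitor), compound 1 gives > 180000 nM, which is a limit of the assay rather than a number. Compound 2 `Cc1cc(Nc2cccc(Cl)c2Cl)nc(N)n1` carries chloro in place of hydrogen on an aromatic carbon, and in this assay compound 2 gives > 180000 nM, again a limit of the assay. Within the data shown here, the one measured step, a step that the two limits leave unreadable from compound 1 to compound 2, therefore cannot be read in size or direction, because the limit of > 180000 nM in this assay, at which 2 of the 2 values shown sit, holds both values shown, so compound 1 stands at that limit and nowhere more precise.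

The unmeasured compound 3 `Cc1cc(Nc2cc(Cl)cc(-c3cncnc3)c2)nc(N)n1` differs from compound 1 by pyrimidin-5-yl in place of hydrogen on an aromatic carbon. Among the measured compounds shown here, no measured step bears on this change in a readable way: the only step in hand is the one from compound 1 to compound 2, and it sits entirely at the limit. With nothing to move from, he expects compound 3 to remain weak, with the step of an at least 1.2-fold lower number from compound 1 to compound 3 (0.07 log units; that floor lies within the scatter) estimated as no more than scatter. For compound 3 in this assay he estimates 150000 nM, within 30000 nM to 600000 nM.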

Compound 3, half-maximal inhibitory concentration: > 180000 nM
Compound 3: no number, only a limit; the forecaster's own chance of this, stated with the estimate: 60%; at least 1.2-fold (0.07 log units) between middle value and limit.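

Compound 3 gives only a limit in this assay, as compound 1 does, so no new step can be read between them in size or direction: the limit of > 180000 nM in this assay, at which 3 of the 3 values shown sit. The compounds shown leave open whether any change on the core of compound 1 gives a readable number in this assay at all.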